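Methylating the phenol of compound 2: an unmeasured step

The source may hold more compounds than are shown below. What is called first, only, known or untested is meant among the compounds shown, and "the series" means these compounds.

Measured compounds:
compound 1 `O=C(Nc1cccc(-n2cc(-c3ccncc3)c(-c3cc(O)cc(Cl)c3)n2)c1)Nc1ccc(Cl)c(C(F)(F)F)c1`: 23.8%
compound 2 `O=C(Nc1cccc(-n2cc(-c3ccncc3)c(-c3cc(O)cc(Cl)c3)n2)c1)Nc1ccc(Cl)c(Cl)c1`: -53.1%

In a functional assay on SK-MEL-5 cells (Homo sapiens) for inhibition, read by sulforhodamine B assay, with a stated time of 48 h, tested at 10 uM (on this read-out lower numbers stand for a stronger effect and higher numbers for a weaker effect at the one concentration tested), compound 1 gives 23.8%. In this assay compound 2 gives -53.1%, the lowest of the two numbers shown, and the only measured step, a number 76.9 percentage points lower from compound 1 to compound 2 (beyond the scatter), separates it from compound 1. Compound 3 `COc1cc(Cl)cc(-c2nn(-c3cccc(NC(=O)Nc4ccc(Cl)c(Cl)c4)c3)cc2-c2ccncc2)c1` has not been measured. It differs from compound 2 by methyl in place of hydrogen on an oxygen on an aromatic ring. Going by the values given here, no measured step touches that oxygen; the step from compound 1 to compound 2 concerns a different place and so gives no guide to the size or direction of this change. With nothing to point either way, the expectation for compound 3 in this assay is a step of a number 8.1 percentage points higher from compound 2 to compound 3 (within the scatter), that is, none beyond the scatter, with wide uncertainty. Compound 3 is therefore estimated at -45%, within a range from -85% to 5%.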

Compound 3, a percentage reported as activity, at one concentration (the size of the read-out at that concentration, not a potency): 3.51%
Compound 3: the middle estimate sits 48.5 percentage points below what was measured, within the range that was stated.
By their numbers in this assay, from the lowest: compound 2; then compound 3; then compound 1.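

Capping the phenol oxygen of compound 2 as its methyl ether is not a silent change: in this assay, hydroxy to methoxy on the 3-chloro-5-hydroxyphenyl group gives a number 56.6 percentage points higher from compound 2 to compound 3 (beyond the scatter), so the effect at the one concentration tested is weaker with methoxy. This shows that the oxygen substituent on this ring, a place untouched by the earlier step, also moves the read-out beyond the scatter, and that the free hydroxy goes with the stronger effect in this pair. Nothing available explains why this change has such an effect.

The compounds shown leave open whether a longer chain on the oxygen, such as ethoxy, or an amine in place of the hydroxy would give a similar number. They also leave open whether methylating the phenol of compound 1, which carries trifluoromethyl, would produce a step of similar size and direction.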